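From aminomethyl to 1-hydroxyethyl on a carbonyl carbon

This account rests on a few compounds, and the source may have more. Where it says the series, first, only, none or still open, it means among the compounds named here.

In a functional assay on U-87MG ATCC cells (Homo sapiens) for antiproliferative activity (on this read-out higher numbers stand for weaker inhibition and lower numbers for stronger inhibition), compound 1 (`Cc1c2c(n3c1CCCNC[C@H](C)Nc1cc-3ccc1C(N)=O)CC(C)(C)CC2=O`) gives 366 nM and compound 2 (`Cc1c2c(n3c1CCN(C(=O)CN)C[C@@H](C)[C@H](C)Nc1cc-3ccc1C(N)=O)CC(C)(C)CC2=O`) gives 378 nM in the same read-out, so the two stand within the usual scatter of each other. Compound 3 (`Cc1c2c(n3c1CCN(C(=O)[C@H](C)O)C[C@@H](C)[C@H](C)Nc1cc-3ccc1C(N)=O)CC(C)(C)CC2=O`) carries 1-hydroxyethyl in place of aminomethyl on a carbonyl carbon. Among the measured compounds shown here, no measured pair shows this change, so compound 2 at 378 nM is the only guide. The estimate puts a 1.3-fold lower number from compound 2 to compound 3 (0.10 log units; within the scatter) within the scatter in this assay and gives it no firm direction. Compound 3 is expected at 300 nM (100 nM to 900 nM).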

Compound 3, half-maximal inhibitory concentration: 88 nM
For compound 3 the middle estimate is 3.4-fold (0.53 log units) above the measured one, outside the stated range (below it).
By their numbers in this assay, from the lowest: compound 3; then compounds 1 and 2 (each within the scatter of the next).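

In this assay, among the compounds shown here, the step of a 4.3-fold lower number from compound 2 to compound 3 (0.63 log units; beyond the scatter) is modest but beyond the scatter, which shows for the first time that a change on this carbonyl carbon, whose other neighbour is the amide-type nitrogen in a ring, moves the read-out. The two groups carry the same counts of hydrogen-bond donors and acceptors, so those counts alone do not track the step. Nothing shown explains it.

On these data alone, it remains open whether the step belongs to the hydroxyl, the added methyl or the defined stereocentre. Hydroxymethyl and the opposite 1-hydroxyethyl stereoisomer would separate these, and a longer chain would test how far the trend extends.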